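Chain extension from compound 2 to compound 4

A few compounds are considered here, and "the series" means these few. Any claim that something is new, unique, unknown or untested is made for them only; others in the source may bear on it.

compound 1 `COc1ccc(-c2cc(=O)c3ccc(O)cc3o2)cc1OC` (22.4 nM)
compound 2 `COc1ccc(-c2cc(=O)c3ccc(OCCCCN4CCC(CCO)CC4)cc3o2)cc1` (23.2 nM)
compound 3 `COc1ccc(-c2cc(=O)c3ccc(OCCCCCN4CCC(C)CC4)cc3o2)cc1` (31.7 nM)

In a functional assay, read by spectrophotometry (on this read-out lower numbers stand for an effect already at smaller amounts and higher numbers for an effect only at larger amounts of compound), compound 2 (23.2 nM) stands level with compound 1 (22.4 nM) and compound 3 (31.7 nM). Its gaps to both lie within the scatter, so no order can be read from them.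

Compound 4 `COc1ccc(-c2cc(=O)c3ccc(OCCCCCCCN4CCC(CCO)CC4)cc3o2)cc1` is still unmeasured. The change from compound 2 is a group of 12 heavy atoms (10 carbon, 1 nitrogen, 1 oxygen; one six-membered non-aromatic ring with 1 hetero atom) in place of a group of 9 heavy atoms (7 carbon, 1 nitrogen, 1 oxygen; one six-membered non-aromatic ring with 1 hetero atom), on a saturated chain carbon, four bonds along the chain from an oxygen on an aromatic ring and neither group carries a net charge.

For the measured compounds named here, one measured step bears on this place on the chain. It is a 1.4-fold higher number from compound 2 to compound 3 (0.14 log units; within the scatter) and it comes with (4-methylpiperidin-1-yl)methyl in place of 4-(2-hydroxyethyl)piperidin-1-yl. Going by the values given here, that step stays within the scatter, but its entering group is not the one in compound 4, and no measured step covers a group of that size. The basis is therefore thin.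

In this assay no step beyond the scatter is expected, with a higher number as the slightly likelier direction. The expected size is a 1.4-fold higher number from compound 2 to compound 4 (0.14 log units; within the scatter) as an estimate. For compound 4 the estimate is 32 nM with an expected range from 12 nM to 85 nM on this evidence.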

Compound 4, half-maximal effective concentration: 35.7 nM
Beside the measured number, compound 4's estimate is 1.1-fold (0.05 log units) below it, and the stated range covers the measured number.
By their numbers in this assay, from the lowest: compounds 1, 2, 3 and 4 (each within the scatter of the next).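

Working notes on the chain: in this assay, the group of 12 heavy atoms in place of the group of 9 heavy atoms gives a 1.5-fold higher number from compound 2 to compound 4 (0.19 log units; within the scatter), the first step shown in which 4-(2-hydroxyethyl)piperidin-1-yl stays at the end of the chain and only the chain differs. The second new step gives a 1.1-fold higher number from compound 3 to compound 4 (0.05 log units; within the scatter), so on this read-out neither comparison separates compound 4 from its neighbours in the series, and the larger group sits at the same level as the smaller ones. No measurement shown bears on what lies behind these numbers.

The compounds shown leave open whether a still longer chain, or a shorter chain than in compound 2, would give a step beyond the scatter. They also leave open how a carboxylic acid or a primary amine in place of the 2-hydroxyethyl group would read at the end of the longer chain of compound 4.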